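The compounds below may be only part of what the source reports. "The series", "measured", "known", "first", "only" and "open" are said of these compounds alone.

In a functional assay on MCF7 cells (Homo sapiens) for antiproliferative activity, read by MTT assay, with a stated time of 48 h (on this read-out higher numbers stand for weaker inhibition and lower numbers for stronger inhibition), two compounds of this series have been measured so far. Compound 1 (`COc1ccc(-c2nc(SCC(=O)c3sc(-c4ccccc4)nc3C)nc(N)c2C#N)cc1`) gives 27200 nM, and compound 2 (`COc1ccc(-c2nc(C)c(C(=O)CSc3nc(N)c(C#N)c(-c4ccc(Cl)cc4)n3)s2)cc1`) gives 11300 nM, the lower of the two numbers, with a gap to compound 1 that lies beyond the usual scatter. These two compounds differ in more than one place, so their gap cannot be tied to any single change. Compound 3 (`Cc1nc(-c2ccccc2)sc1C(=O)CSc1nc(N)c(C#N)c(-c2ccc(Cl)cc2)n1`) departs from compound 2 in one place, with hydrogen in place of methoxy on an aromatic carbon. Among the compounds with values here, no measured pair shows this change alone, so only a small move towards a higher number is expected in this assay, possibly none beyond the scatter. The expected size of the move is a 1.3-fold higher number from compound 2 to compound 3 (0.12 log units; within the scatter). For compound 3 the estimated value is 15000 nM, within an expected range of 6000 nM to 40000 nM.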

Compound 3, half-maximal inhibitory concentration: 20200 nM
Compound 3: the middle estimate sits 1.3-fold (0.13 log units) below what was measured; measured number inside the range.
By their numbers in this assay, from the lowest: compounds 2, 3 and 1 (each within the scatter of the next, the first and the last beyond it).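

Read in this assay, the change from 4-methoxyphenyl to phenyl gives a 1.8-fold higher number from compound 2 to compound 3 (0.25 log units; within the scatter) and so stays within the scatter, which means that this position, para to a large group, shows no readable response to losing methoxy. Chloro in place of methoxy, at the other place where compound 1 and compound 2 differ, gives a 1.3-fold lower number from compound 1 to compound 3 (0.13 log units; within the scatter) and also stays within the scatter. No measurement offered here explains either step.

At the first position only methoxy and hydrogen appear among the compounds shown, so it remains open whether an amine, a carboxylic acid or a longer chain such as butoxy would move the number beyond the scatter. On these data alone, at the second, it remains open how fluoro or an amine would compare with chloro and methoxy.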